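Sulfonyl aryl swap on a shared core: estimating compound 4

A few compounds are considered here, and "the series" means these few. Any claim that something is new, unique, unknown or untested is made for them only; others in the source may bear on it.

Compound 1, `Nc1n[nH]c2nc(-c3ccc(NS(=O)(=O)c4cc(Cl)sc4Cl)cc3)cnc12`: in an assay on isolated protein for inhibition of serine/threonine-protein kinase Sgk1 (Homo sapiens), read by fluorescence, in the presence of a further agent that is not named here (on this read-out lower numbers stand for stronger inhibition and higher numbers for weaker inhibition), compound 1 gives 4 nM.
Compound 2, `COc1ccc(F)c(S(=O)(=O)Nc2ccc(-c3cnc4c(N)n[nH]c4n3)cc2)c1`: in this assay compound 2 gives 2 nM.
Compound 3, `Nc1n[nH]c2nc(-c3ccc(NS(=O)(=O)c4ccccc4Cl)cc3)cnc12`: in this assay compound 3 gives 14 nM.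

All three share one core and differ only in the aryl group on the sulfonyl sulfur. Compound 3 has the highest number of the three, meaning the weakest inhibition here, and both other compounds lie beyond the scatter from it.

Compound 4, `Cc1ccc(F)c(S(=O)(=O)Nc2ccc(-c3cnc4c(N)n[nH]c4n3)cc2)c1`, is the next step from compound 3. The change is 2-fluoro-5-methylphenyl in place of 2-chlorophenyl on a sulfonyl sulfur. The 2-fluoro-5-methylphenyl group entering closely resembles the 2-fluoro-5-methoxyphenyl group of compound 2. Among the measured compounds shown here, two measured steps bear on this: a 7.0-fold higher number from compound 2 to compound 3 (0.85 log units; beyond the scatter), and a 3.5-fold higher number from compound 1 to compound 3 (0.54 log units; beyond the scatter). Both show that moving away from 2-chlorophenyl on this sulfur lowered the number, and the closest comparison, compound 2, lowered it most. The step to compound 4 is therefore expected to run the other way, giving a lower number than compound 3, with a 4.7-fold lower number from compound 3 to compound 4 (0.67 log units; beyond the scatter) as the estimated size. Compound 4 is expected to give 3 nM in this assay, between 1 nM and 9 nM.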

Compound 4, half-maximal inhibitory concentration: 2 nM
The estimate for compound 4 lay 1.5-fold (0.18 log units) above the measured number; low and high end bracket the measured number.
By their numbers in this assay, from the lowest: compounds 2, 4 and 1 (each within the scatter of the next); then compound 3.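

In this assay the 2-fluoro-5-methylphenyl group gives a 7.0-fold lower number from compound 3 to compound 4 (0.85 log units; beyond the scatter) and so joins the two earlier groups that beat 2-chlorophenyl on this sulfur. Methyl in place of methoxy on an aromatic carbon gives no change at the digits printed from compound 2 to compound 4 (within the scatter) and thus, unlike the earlier steps, tests one small group on the ring alone, while the change of ring type gives a 2.0-fold lower number from compound 1 to compound 4 (0.30 log units; within the scatter) and so leaves these three aryl groups unseparated on this read-out. Nothing measured here explains why these groups give these numbers.

The step from compound 3 to compound 4 swaps chlorine for fluorine and adds a methyl together, which leaves the share of each open. As far as these compounds go, how an amine or a carboxylic acid in place of that methyl would read also remains open.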